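Nitro for Chloro: Expecting the Cytotoxicity of Compound 4

A few compounds are considered here, and "the series" means these few. Any claim that something is new, unique, unknown or untested is made for them only; others in the source may bear on it.

Compound 1, `Cc1ccc(-c2nnc(N3CCN(C(=O)CN4CCN(c5ccc(Cl)cc5)CC4)CC3)nc2-c2ccc(C)cc2)cc1`, in a functional assay on MCF7 cells (Homo sapiens) for cytotoxicity, read by MTT assay, with a stated time of 24 h (on this read-out higher numbers stand for weaker inhibition and lower numbers for stronger inhibition), gives 660000 nM.
Compound 2, `Cc1ccc(-c2nnc(N3CCN(C(=O)CN4CCN(c5ccc([N+](=O)[O-])cc5)CC4)CC3)nc2-c2ccc(C)cc2)cc1`, in this assay gives 845000 nM.
Compound 3, `COc1ccc(-c2nnc(N3CCN(C(=O)CN4CCN(c5ccc(Cl)cc5)CC4)CC3)nc2-c2ccc(OC)cc2)cc1`, in this assay gives 607000 nM.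

Compound 2 arises from compound 1 by one change, (nitro in place of chloro on an aromatic carbon), and the step that change made was a 1.3-fold higher number from compound 1 to compound 2 (0.11 log units; within the scatter). Compound 3 shares this general build with compound 1, but the difference between the two cores is not broken down here. Compound 4, `COc1ccc(-c2nnc(N3CCN(C(=O)CN4CCN(c5ccc([N+](=O)[O-])cc5)CC4)CC3)nc2-c2ccc(OC)cc2)cc1`, has not yet been tested; it arises from compound 3 by the same change, (nitro in place of chloro on an aromatic carbon), at the same place. Because the earlier swap gave a 1.3-fold higher number from compound 1 to compound 2 (0.11 log units; within the scatter), the step expected here is a 1.3-fold higher number from compound 3 to compound 4 (0.11 log units; within the scatter). For compound 4 the estimate is 780000 nM, expected to lie between 450000 nM and 1350000 nM.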

Compound 4, half-maximal inhibitory concentration: > 801000 nM
Compound 4: only a limit was reported; the forecaster's own chance of this, stated with the estimate: 10%; middle value at least 1.0-fold (0.01 log units) from the limit.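

For compound 4 this assay reports only the limit > 801000 nM and no exact number. Putting nitro in place of chloro on this second core gives an at least 1.3-fold higher number from compound 3 to compound 4 (0.12 log units; that floor lies within the scatter) and, set beside the same change on the first core, the comparison reads: the same change on two cores in this assay, a 1.3-fold higher number (0.11 log units; within the scatter) from compound 1 to compound 2 and an at least 1.3-fold higher number (0.12 log units; that floor lies within the scatter) from compound 3 to compound 4; the limit leaves it open whether they differ. This fits a change that carries over from one core to the other, but it does not show that the two steps are equal, or that the change moves the number at all on either core.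

The compounds shown leave open how an amine or a carboxylic acid would read in place of chloro or nitro on this ring. They also leave open whether the change would behave alike on a core carrying a longer chain in place of the methyl or methoxy groups.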